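Ring contraction on the fused bicycle and hepatic clearance

The compounds below may be only part of what the source reports. "The series", "measured", "known", "first", "only" and "open" are said of these compounds alone.

The series shares an acetamido-cyclohexane carboxamide attached to a pyridine that carries a bicyclic group. Compound 1 `CC(=O)N[C@@H]1CCC[C@H](C(=O)Nc2cc(-c3cnn4c3CCCC4)c(Cl)cn2)C1` carries a six-membered saturated ring fused to the five-membered aromatic ring. In an ADME assay on cells (Hepatocyte, Homo sapiens) for metabolic stability, using equilibrium dialysis (on this read-out higher numbers stand for fast clearance and lower numbers for slow clearance), compound 1 gives < 1.2 uL/min, a limit of the assay rather than a number. For the measured compounds named here, compound 2 `CC(=O)N[C@@H]1CCC[C@H](C(=O)Nc2cc(-c3cnn4c3CCCCC4)c(Cl)cn2)C1` widens that saturated ring to seven members, and in this assay compound 2 gives 4.6 uL/min; among the three values shown this is the only one reported as a number. Compound 3 `CC(=O)N[C@@H]1CCC[C@H](C(=O)Nc2cc(-c3cnn4c3CC(C)(C)C4)ccn2)C1`, which lacks the chloro group and carries a gem-dimethyl five-membered ring, gives < 1 uL/min in this assay, again a limit. Going by the values given here, the one measured step, an at least 3.8-fold higher number from compound 1 to compound 2 (0.58 log units; beyond the scatter), shows that the wider saturated ring went with faster clearance, although a limit sits at one end of it, as the limit of < 1.2 uL/min in this assay, at which 1 of the 3 values shown sits, and the limit of < 1 uL/min in this assay, at which 1 of the 3 values shown sits, note.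

Compound 4 `CC(=O)N[C@@H]1CCC[C@H](C(=O)Nc2cc(-c3cnc4n3CC(C)(C)C4)c(Cl)cn2)C1` has the same atoms as compound 2 but arranged differently: a group of 10 heavy atoms (8 carbon, 2 nitrogen; one five-membered non-aromatic ring with 1 hetero atom, one five-membered aromatic ring with 2 hetero atoms) in place of a group of 10 heavy atoms (8 carbon, 2 nitrogen; one five-membered aromatic ring with 2 hetero atoms, one seven-membered non-aromatic ring with 1 hetero atom), on an aromatic carbon. The measured step from compound 1 to compound 2 bears on this change, since it moves the saturated ring in the opposite direction, toward fewer members, and compound 3 with its five-membered ring sits at a limit. Compound 4 is therefore expected to clear more slowly than compound 2, an expected step of a 3.1-fold lower number from compound 2 to compound 4 (0.49 log units; beyond the scatter), and the estimate for compound 4 is 1.5 uL/min, between 0.8 uL/min and 3.5 uL/min.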

Compound 4, intrinsic clearance in a liver preparation (reported as CLH), per the amount of preparation that the assay uses: 2.5 uL/min
For compound 4 the middle estimate is 1.7-fold (0.22 log units) below the measured one; the range from low to high includes it.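

Exchanging the seven-membered non-aromatic ring for the five-membered non-aromatic ring, with the same atoms joined differently, gives a 1.8-fold lower number from compound 2 to compound 4 (0.26 log units; within the scatter), so this assay does not tell these two groups apart at this aromatic carbon, ortho to a chloro group and opposite the ring nitrogen. The other new comparison, with the six-membered non-aromatic ring, runs the opposite way to a simple ordering by ring size, with an at least 2.0-fold higher number from compound 1 to compound 4 (0.31 log units; beyond the scatter), so across compound 1, compound 2 and compound 4 the number does not follow the count of ring members. On these data alone, that comparison has a limit at one end, so its true size stays unknown: the limit of < 1.2 uL/min in this assay, at which 1 of the 4 values shown sits.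

The change to compound 4 alters the ring size and the arrangement of the aromatic ring together, so the compounds shown do not separate the contribution of each. They also leave open how this assay would respond to an oxygen atom within the saturated ring, or to a fluoro group or a nitrile in the place of the chloro group.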